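Adding a Second Trifluoromethyl to Compound 1

The compounds below may be only part of what the source reports. "The series", "measured", "known", "first", "only" and "open" are said of these compounds alone.

Compound 1 `O=C(Nc1cccc(-n2cc(-c3ccncc3)c(-c3ccc(Cl)c(O)c3)n2)c1)Nc1cccc(C(F)(F)F)c1`: 22500 nM in a functional assay on PC-3 cells (Homo sapiens) for inhibition, read by sulforhodamine B assay, with a stated time of 48 h; a lower number here means a stronger inhibitor of growth, a higher number a weaker inhibitor of growth.
Compound 2 `O=C(Nc1cccc(-n2cc(-c3ccncc3)c(-c3ccc(Cl)c(O)c3)n2)c1)Nc1ccc(Cl)c(Cl)c1`: in this assay the assay reports only a limit, > 32500 nM.

Compound 1 holds the only full number shown; the other value is a limit, as the limit of > 32500 nM in this assay, at which 1 of the 2 values shown sits, records. Among the measured compounds shown here, the single measured step, an at least 1.4-fold higher number from compound 1 to compound 2 (0.15 log units; that floor lies within the scatter), swaps the whole aromatic group on the amide-type nitrogen, and its floor stays within the usual scatter, so it gives no firm direction. Compound 3 `O=C(Nc1cccc(-n2cc(-c3ccncc3)c(-c3ccc(Cl)c(O)c3)n2)c1)Nc1cc(C(F)(F)F)cc(C(F)(F)F)c1` keeps everything of compound 1 and differs only by trifluoromethyl in place of hydrogen on an aromatic carbon. For the measured compounds named here, since the one comparable change left compound 1 at worst slightly weakened, the expectation for compound 3 in this assay is a step of a 1.2-fold higher number from compound 1 to compound 3 (0.09 log units; within the scatter), that is, no clear change beyond the scatter, with some chance of only a limit being reported. Compound 3 is therefore estimated at 28000 nM, between 11000 nM and 70000 nM.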

Compound 3, concentration for total growth inhibition: 4370 nM
The estimate for compound 3 lay 6.4-fold (0.81 log units) above the measured number, outside the stated range (below it).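

In this assay, the aromatic carbon that is meta to a large group and meta to a trifluoromethyl group proves sensitive to substitution: trifluoromethyl in place of hydrogen there gives a 5.1-fold lower number from compound 1 to compound 3 (0.71 log units; beyond the scatter), a shift towards stronger inhibition of growth. The earlier step replaced the whole aromatic group and gave no firm direction, whereas this change in a single place gives a clear one. No measurement shown explains why the number falls.

From the compounds shown here alone, whether a nitrile, an amine or a methyl at this carbon would also lower the number remains open. Among the compounds shown here, the change appears in only one pair, so nothing shows whether it would hold on a ring lacking the trifluoromethyl already present in compound 1.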